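Cyano for chloro on a pyridyl ether azetidine

The source may report more compounds than this note shows. Statements on the series, on what has been measured and on what is new or still open speak of the compounds shown alone.

Compound 1 `Brc1ccc(OC[C@@H]2CCN2)cn1` gives 0.021 nM in an assay on brain for binding affinity to Neuronal acetylcholine receptor; alpha4/beta2 (Rattus norvegicus), read by radioligand binding (a lower number here means a stronger inhibitor, a higher number a weaker inhibitor), while compound 2 `CCc1ccc(OC[C@@H]2CCN2)cn1` gives 19 nM; the step of a 900-fold higher number from compound 1 to compound 2 (2.96 log units; beyond the scatter) is the only one recorded among the measured pairs. Compound 3 `Clc1cncc(OC[C@@H]2CCN2)c1` gives 0.042 nM, which sits within the scatter of compound 1 and far from compound 2. Compound 4 `N#Cc1cncc(OC[C@@H]2CCN2)c1` differs from compound 3 by cyano in place of chloro on an aromatic carbon. For the measured compounds named here, no measured step replaces a halogen with cyano, and the bromo-to-ethyl step concerns a different group, so it bears only loosely on the question. Compound 4 is therefore expected to keep a very low number, with an estimated step of a 2.4-fold higher number from compound 3 to compound 4 (0.38 log units; beyond the scatter) that should stay modest. Compound 4 is estimated at 0.1 nM, within a range of 0.02 nM to 0.6 nM.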

Compound 4, inhibition constant: 0.025 nM
Estimate against measurement, compound 4: 4.0-fold (0.60 log units) above, within the range that was stated.
By their numbers in this assay, from the lowest: compounds 1, 4 and 3 (each within the scatter of the next); then compound 2.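

On the aromatic carbon two atoms from the ring nitrogen, cyano replaces chloro with a 1.7-fold lower number from compound 3 to compound 4 (0.23 log units; within the scatter) in this assay and the number stays within the scatter. This position therefore tolerates the nitrile, with its hydrogen-bond acceptor and extra heavy atom, which the large bromo-to-ethyl step, a change of other groups, could not show. No evidence available here accounts for this result.

Going by these compounds, whether an amine, a carboxylic acid or a longer chain on this carbon would also stay within the scatter of compound 3 remains open.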